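From oxan-4-yl to 2-methylphenyl on the shared core

The source may hold more compounds than are shown below. What is called first, only, known or untested is meant among the compounds shown, and "the series" means these compounds.

Compound 1 `O=C(CC1CCCCCC1)N1CCC(c2nc(-c3ccc4ccccc4n3)no2)CC1` – 840 nM
Compound 2 `O=C(NC1CCOCC1)N1CCC(c2nc(-c3ccc4ccccc4n3)no2)CC1` – 480 nM

For the measured compounds named here, in a functional assay on Shh Light II cells (Mus musculus) for inhibition, read by a luciferase reporter (on this read-out lower numbers stand for stronger inhibition and higher numbers for weaker inhibition), compound 2 stands at 480 nM and cannot be told apart from compound 1, the only other measured compound. Going by the values given here, the single measured step between them is a 1.8-fold lower number from compound 1 to compound 2 (0.24 log units; within the scatter).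

Still to be measured is compound 3 `Cc1ccccc1NC(=O)N1CCC(c2nc(-c3ccc4ccccc4n3)no2)CC1`, which keeps the shared core and changes one group: 2-methylphenyl in place of oxan-4-yl on an amide-type nitrogen. Here 2-methylphenyl stands in place of oxan-4-yl on an amide-type nitrogen. Among the compounds with values here, the one measured step bears on this only loosely, since it also exchanged the group on the same carbonyl carbon, with (oxan-4-yl)amino replacing cycloheptylmethyl. Within the data shown here, no measured compound carries a 2-methylphenyl group, so the data give no direction for this change. The expectation rests on compound 2 and its small step, a 1.8-fold lower number from compound 1 to compound 2 (0.24 log units; within the scatter), and no step beyond the scatter is foreseen in this assay. The expected change is a 1.1-fold lower number from compound 2 to compound 3 (0.03 log units; within the scatter), though the uncertainty is wide. For compound 3 the estimated value is 450 nM, with an expected range from 150 nM to 1300 nM.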

Compound 3, half-maximal inhibitory concentration: 440 nM
Compound 3: middle estimate off by 1.0-fold (0.01 log units), on the high side; the measured number falls inside the stated range.
By their numbers in this assay, from the lowest: compounds 3, 2 and 1 (each within the scatter of the next).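

In this assay, the exchange of oxan-4-yl for 2-methylphenyl on the amide-type nitrogen gives a 1.1-fold lower number from compound 2 to compound 3 (0.04 log units; within the scatter), so a six-membered aromatic ring of carbon only and a six-membered non-aromatic ring with a hetero atom cannot be told apart at this place. The wider comparison in this assay, with (2-methylphenyl)amino in place of cycloheptylmethyl on a carbonyl carbon, gives a 1.9-fold lower number from compound 1 to compound 3 (0.28 log units; within the scatter), so none of the three groups on this carbonyl carbon separates from the others, even though they include both aromatic and non-aromatic rings and both a urea-type and a plain amide-type link. Nothing at hand speaks to why such different groups give readings within the scatter of one another.

The compounds shown leave open whether the methyl group of 2-methylphenyl contributes anything, a question that a plain phenyl on the same nitrogen could settle. Also open, on these data alone, is whether a carboxylic acid or a primary amine carried on a short chain at that nitrogen would move the number beyond the scatter, which none of the three groups seen so far does.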